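From 1H-benzimidazol-1-yl to pyrimidin-5-yl on compound 3

The source may report more compounds than this note shows. Statements on the series, on what has been measured and on what is new or still open speak of the compounds shown alone.

Three compounds have so far been taken into a functional assay on CWR22R cells (Homo sapiens) for antiproliferative activity, read by CCK-8 assay, with a stated time of 6 days (on this read-out higher numbers stand for weaker inhibition and lower numbers for stronger inhibition), and two of them have numbers. Compound 1 (`N#Cc1ccc(N2CCc3cc(-c4cccnc4)ccc32)cc1C(F)(F)F`) has "not determined" (no result reported) as its entry, so it offers no comparison. Compound 2 (`N#Cc1ccc(N2CCCc3c(-c4cccnc4)cccc32)cc1C(F)(F)F`) gives 12300 nM in this assay and compound 3 (`CCN(c1ccc(C#N)c(Cl)c1)c1cc(-n2cnc3ccccc32)ccc1C`) gives 3040 nM in the same read-out. Compound 3 therefore holds the lower of the two numbers, and the gap to compound 2 lies beyond the usual scatter.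

The next compound is compound 4 (`CCN(c1ccc(C#N)c(Cl)c1)c1cc(-c2cncnc2)ccc1C`), which has pyrimidin-5-yl in place of 1H-benzimidazol-1-yl on an aromatic carbon, para to a methyl group (pyrimidin-5-yl in place of 1H-benzimidazol-1-yl on an aromatic carbon). The rest of compound 3 is unchanged. Among the compounds with values here, no measured pair differs in one place, so no earlier step shows what this exchange does. Within the data shown here, the only firm anchor is compound 3 at 3040 nM on the same core, and the expectation rests on that value and on the structural change alone.

A moderate shift towards a higher number, meaning weaker inhibition, is expected, with a 2.3-fold higher number from compound 3 to compound 4 (0.36 log units; beyond the scatter) as the estimated step. For compound 4 the estimated value is 7000 nM in this assay, with an expected range from 2000 nM to 20000 nM around it.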

Compound 4, half-maximal inhibitory concentration: > 30000 nM
Compound 4 was reported as a limit; the forecaster's own chance of this, stated with the estimate: 10%; middle value at least 4.2-fold (0.63 log units) from the limit.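

In this assay, within the data shown here, the exchange of 1H-benzimidazol-1-yl for pyrimidin-5-yl on the aromatic carbon para to a methyl group is the first single-place change, and it gives an at least 9.8-fold higher number from compound 3 to compound 4 (0.99 log units; beyond the scatter). The entry for compound 4 is a limit of the assay and not a number, and it is the only such entry among the compounds shown: the limit of > 30000 nM in this assay, at which 1 of the 4 values shown sits. The two groups have the same counts of hydrogen-bond donors and acceptors and no net charge, so these counts alone do not preserve activity at this position, while the entering group has fewer heavy atoms and no six-membered aromatic ring of carbon only.

This single step cannot separate the loss of the six-membered aromatic ring of carbon only from the replacement of the whole group by a different ring. A phenyl or 1H-indol-1-yl group on the same carbon, with the rest of compound 3 unchanged, would help to separate these two readings.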